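The compounds below may be only part of what the source reports. "The series", "measured", "known", "first", "only" and "open" are said of these compounds alone.

Working notes on the series in a functional assay on HT-29 cells (Homo sapiens) for cytotoxicity, read by MTT assay, with a stated time of 6 days; a higher number here means that more compound is needed for the effect, a lower number that less compound is needed. Within the data shown here, compound 1 `COC(=O)c1c(-c2cc(OC)cc(OC)c2)oc2ccccc2c1=O` gives 6.99 ug/mL, the only true number so far. Compound 2 `COC(=O)c1c(-c2ccc(Br)cc2)oc2ccccc2c1=O` gives > 25 ug/mL, which is a limit and not a number. Compound 3 `COC(=O)c1c(-c2ccc([N+](=O)[O-])cc2)oc2cc(OC)ccc2c1=O` gives > 25 ug/mL, again a limit. From the compounds shown here alone, compound 2 thus stands on (the limit of > 25 ug/mL in this assay, at which 2 of the 3 values shown sit), and its real place beyond that limit is unknown.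

The change to compound 4 `COC(=O)c1c(-c2ccc(OCc3ccccc3)cc2)oc2ccccc2c1=O` is benzyloxy in place of bromo on an aromatic carbon, with benzyloxy in place of bromo on an aromatic carbon, para to a large group. Among the measured compounds shown here, no measured step gives a scale for this change. Compound 1 at 6.99 ug/mL shows that a number can be reached in this series, so a move toward less compound needed is possible. A reading for compound 4 at the limit is about as likely. In this assay the expected step is an at least 1.6-fold lower number from compound 2 to compound 4 (0.22 log units; that floor lies within the scatter), modest and toward a lower concentration. For compound 4 the estimated value is 15 ug/mL, with a range expected from 5 ug/mL to 25 ug/mL.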

Compound 4, concentration for half-maximal effect: > 25 ug/mL
Compound 4 ended at the assay's limit; the forecaster's own chance of this, stated with the estimate: 50%; middle value at least 1.6-fold (0.22 log units) from the limit.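

In this assay compound 2 and compound 4 both give only a limit, so no step can be read between them: the limit of > 25 ug/mL in this assay, at which 3 of the 4 values shown sit.

The compounds shown leave open whether benzyloxy in place of bromo on an aromatic carbon changes the number at all, and where either compound lies beyond the limit.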